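Methoxy in Place of Chloro: Compound 2 to Compound 4

The source may hold more compounds than are shown below. What is called first, only, known or untested is meant among the compounds shown, and "the series" means these compounds.

Of the compounds shown here, three of a shared core have been measured in a functional assay on MGC-803 cells (Homo sapiens) for antiproliferative activity, read by CCK-8 assay, with a stated time of 72 h, tested at 8 uM; on this read-out lower numbers stand for a weaker effect and higher numbers for a stronger effect at the one concentration tested. Compound 1 `Nc1ccccc1NC(=O)c1ccc(CSC(=S)N2CCN(C(c3ccccc3)c3ccccc3)CC2)cc1` gives 9.9% in this assay. Compound 2 `Nc1ccccc1NC(=O)c1ccc(CSC(=S)N2CCN(c3ccc(Cl)cc3)CC2)cc1` gives 17.2% in this assay, the second highest of the three numbers; its nearest neighbour is compound 1, whose value lies within the scatter of it, so no order can be read between the two. Compound 3 `CN(C(=S)SCc1ccc(C(=O)Nc2ccccc2N)cc1)c1cccnc1` gives 82.5% in this assay, a number that stands beyond the scatter above compound 2.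

Compound 4 `COc1ccc(N2CCN(C(=S)SCc3ccc(C(=O)Nc4ccccc4N)cc3)CC2)cc1` has not yet been measured in this assay. It differs from compound 2 in one place: methoxy in place of chloro on an aromatic carbon. Within the data shown here, no pair of measured compounds shows this same change, so the size of the step has no precedent among the numbers at hand. Compound 1 and compound 2 both stand low in this assay, and the rest of the structure is kept unchanged. On that ground the step is expected to be small, with no clear direction, and to stay within the scatter. In this assay compound 4 is therefore expected to give about 20%, with a range from 5% to 45%. The step of a number 2.8 percentage points higher from compound 2 to compound 4 (within the scatter) that this estimate means is expected to be no larger than the usual scatter.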

Compound 4, a percentage reported as inhibition, at one concentration (the size of the read-out at that concentration, not a potency): 22.9%
Estimate against measurement, compound 4: 2.9 percentage points below; low and high end bracket the measured number.
By their numbers in this assay, from the lowest: compounds 1, 2 and 4 (each within the scatter of the next, the first and the last beyond it); then compound 3.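

In this assay, among these compounds, the exchange of 4-chlorophenyl for 4-methoxyphenyl gives the first direct reading of a change at this position, on an aromatic carbon para to a large group, and it comes out as a number 5.7 percentage points higher from compound 2 to compound 4 (within the scatter). Methoxy brings one more heavy atom than chloro and a hydrogen-bond acceptor that chloro does not have, yet at this single concentration these differences do not separate compound 4 from compound 2, so this one exchange gives no order between the two groups. No measurement at hand offers an explanation for this outcome.

The compounds shown leave open whether other groups on this aromatic carbon, such as an amine, a carboxylic acid, a longer alkoxy chain or plain hydrogen, would also stay within the scatter of compound 2, since a single exchange cannot define what the position tolerates. They also leave open whether compound 2 and compound 4 would remain inseparable at another concentration, or in another cell line, because all of these numbers come from one concentration in one cell line.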